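The source may hold more compounds than are shown below. What is called first, only, known or untested is meant among the compounds shown, and "the series" means these compounds.

Compound 1 `CC(C)OC(=O)N1CCC(Oc2ncnc3c2CCN3c2ccc(S(C)(=O)=O)cc2F)CC1` serves as the reference point. In a functional assay on CHO-K1 cells for agonist activity at Glucose-dependent insulinotropic receptor (Homo sapiens), read by a luciferase reporter, with a stated time of 5 h (on this read-out lower numbers stand for an effect already at smaller amounts and higher numbers for an effect only at larger amounts of compound), compound 1 gives 50.1 nM, the higher of the two numbers recorded, and the nearest neighbour is compound 2 `CC(C)COC(=O)N1CCC(Oc2ncnc3c2CCN3c2ccc(S(C)(=O)=O)cc2F)CC1`, which in this assay gives 25.1 nM; the step of a 2.0-fold lower number from compound 1 to compound 2 (0.30 log units; within the scatter) stays within the scatter. Compound 3 `CN(C)C(=O)CN1CCC(Oc2ncnc3c2CCN3c2ccc(S(C)(=O)=O)cc2F)CC1` is reported in this assay only as a limit, > 10000 nM. That limit is the limit of > 10000 nM in this assay, at which 1 of the 3 values shown sits. The steps of an at least 190-fold higher number from compound 1 to compound 3 (2.30 log units; beyond the scatter) and an at least 390-fold higher number from compound 2 to compound 3 (2.60 log units; beyond the scatter) both lie well beyond the scatter.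

Compound 4 `CC(C)OC(=O)N1CCC(Oc2ncnc3c2CCN3c2ccc([S+]([O-])N(C)C)cc2)CC1` has not been measured. It differs from compound 1 by a group of 11 heavy atoms (8 carbon, 1 nitrogen, 1 oxygen, 1 sulfur; one six-membered aromatic ring of carbon only) in place of a group of 11 heavy atoms (7 carbon, 2 oxygen, 1 fluorine, 1 sulfur; one six-membered aromatic ring of carbon only), on a nitrogen on an aromatic ring in a ring. Within the data shown here, none of the measured steps touches this part of the structure; all three alter the substituent on the amine nitrogen in a ring, so no measured step bears directly on the change from compound 1 to compound 4. Among the measured compounds shown here, with no comparable step available, a weakening beyond the scatter is expected, but with wide uncertainty in both directions. The expected step is a 5.0-fold higher number from compound 1 to compound 4 (0.70 log units; beyond the scatter). Compound 4 is estimated at 250 nM, with a range from 40 nM to 2500 nM.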

Compound 4, half-maximal effective concentration: 501 nM
For compound 4 the middle estimate is 2.0-fold (0.30 log units) below the measured one; low and high end bracket the measured number.
By their numbers in this assay, from the lowest: compounds 2 and 1 (each within the scatter of the next); then compound 4. At a limit, above all of these: compound 3.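

In this assay, the aromatic group on a nitrogen on an aromatic ring in a ring proves sensitive to change: replacing the 2-fluoro-4-(methylsulfonyl)phenyl group gives a 10-fold higher number from compound 1 to compound 4 (1.00 log units; beyond the scatter) with the isopropoxycarbonyl on the amine nitrogen in a ring unchanged. Among these compounds, this is the first measured step at this place, and it still leaves compound 4 with a measured number rather than a limit. The entering group lacks the fluorine and carries a dimethylamino-bearing sulfur group instead of methylsulfonyl, and nothing measured here explains the step or separates these two alterations.

Still open, as far as these compounds go, is whether removing the fluorine or altering the sulfur group accounts for the step, and how a nitrile or a carboxylic acid would fare in place of methylsulfonyl. Also open, from the compounds shown here alone, is whether the same exchange would behave alike with the isobutoxycarbonyl of compound 2.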